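From 3,4-Dichlorophenyl to 3,5-Dichlorophenyl

The source may report more compounds than this note shows. Statements on the series, on what has been measured and on what is new or still open speak of the compounds shown alone.

In an ADME assay on NHDF cells (Homo sapiens) for cytotoxicity, read by MTT assay, with a stated time of 72 h (a higher number here means a weaker inhibitor, a lower number a stronger inhibitor), compound 1 (`COc1cccc(/C=C2\CCC/C(=C\c3ccc(OC)c(OC)c3)C2=O)c1`) stands at 11600 nM and compound 2 (`COc1ccc(/C=C2\CCC/C(=C\c3ccc(O)cc3)C2=O)cc1OC`) at 26100 nM while compound 3 (`COc1ccc(/C=C2\CCC/C(=C\c3ccc(Cl)c(Cl)c3)C2=O)cc1OC`) stands at 10100 nM in this small series. Compound 3 is level with one neighbour, as the data show a 1.1-fold lower number from compound 1 to compound 3 (0.06 log units; within the scatter) and it is set apart from the other by a 2.6-fold lower number from compound 2 to compound 3 (0.41 log units; beyond the scatter) at the same place. Compound 4 (`COc1ccc(/C=C2\CCC/C(=C\c3cc(Cl)cc(Cl)c3)C2=O)cc1OC`) carries 3,5-dichlorophenyl in place of 3,4-dichlorophenyl on a double-bonded chain carbon bound to a double-bonded ring carbon. Going by the values given here, no measured step covers this exact swap. The nearest evidence is that changes at this place have stayed modest, with a 2.3-fold higher number from compound 1 to compound 2 (0.35 log units; beyond the scatter) as the remaining step, and those changes replaced one group with a different one. Here the same atoms are merely joined differently, so no step beyond the scatter is expected, and the estimated change is a 1.0-fold higher number from compound 3 to compound 4 (0.02 log units; within the scatter) in size. For compound 4 the estimated value is 10500 nM with an expected range from 5500 nM to 20000 nM in this assay when measured.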

Compound 4, half-maximal inhibitory concentration: 8300 nM
Compound 4: middle estimate off by 1.3-fold (0.10 log units), on the high side; the measured number falls inside the stated range.
By their numbers in this assay, from the lowest: compounds 4, 3 and 1 (each within the scatter of the next); then compound 2.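

In this assay, 3,5-dichlorophenyl in place of 3,4-dichlorophenyl gives a step that cannot be told from the scatter (a 1.2-fold lower number from compound 3 to compound 4 (0.09 log units; within the scatter)), so at this position the same atoms joined differently leave the number unchanged within the scatter. Going by these compounds alone, the new compound also stays level with the 3-methoxyphenyl compound (a 1.4-fold lower number from compound 1 to compound 4 (0.15 log units; within the scatter)), while the 4-hydroxyphenyl compound remains set apart (a 3.1-fold lower number from compound 2 to compound 4 (0.50 log units; beyond the scatter)), the largest step at this place so far, which leaves 4-hydroxyphenyl as the only group here whose number separates from the others. Nothing available here bears on what lies behind these numbers.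

From the compounds shown here alone, whether a single chlorine, a trifluoromethyl group or an amine on the phenyl ring at this place would stay level with compound 3 and compound 4 remains open. So does whether a carboxylic acid there would move the number as far as 4-hydroxyphenyl did.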